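This account rests on a few compounds, and the source may have more. Where it says the series, first, only, none or still open, it means among the compounds named here.

Measured so far:
compound 1 `CCN(CC)S(=O)(=O)c1ccc(S(=O)(=O)N2CCC[C@@H](C(=O)N[C@H]3CC[C@H](OC)CC3)C2)cc1` — 1350 nM
compound 2 `CCN(CC)S(=O)(=O)c1ccc(S(=O)(=O)N2CCC[C@@H](C(=O)N[C@H]3CC[C@@H](OC)CC3)C2)cc1` — 960 nM

In a functional assay on MIA PaCa-2 cells (Homo sapiens) for inhibition, read by MTT assay, with a stated time of 7 days (a higher number here means a weaker inhibitor, a lower number a stronger inhibitor), compound 1 gives 1350 nM and compound 2 gives 960 nM. The step of a 1.4-fold lower number from compound 1 to compound 2 (0.15 log units; within the scatter) rests on (the fact that compounds 1 and 2 differ only in the configuration as drawn); the two numbers are indistinguishable within the scatter, so compound 2 stands level with compound 1 rather than apart from it.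

Compound 3 `CCN(CC)S(=O)(=O)c1ccc(S(=O)(=O)N2CCC[C@@H](C(=O)N3CC[C@@H](OC)C3)C2)cc1` carries a different amide end: 3-methoxypyrrolidin-1-yl in place of (4-methoxycyclohexyl)amino on a carbonyl carbon. Going by the values given here, this is a change of the group on the carbonyl carbon, not a change of configuration, and the only measured step, the one from compound 1 to compound 2, does not bear on it. Among the compounds with values here, there is therefore no measured step from which the size or direction of the step in this assay can be read; the expectation is a step of unknown direction and a wide range around the value of compound 2.

For compound 3 the expected value in this assay is 1500 nM, within 450 nM to 6000 nM, which means an estimated step of a 1.6-fold higher number from compound 2 to compound 3 (0.19 log units; within the scatter).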

Compound 3, half-maximal inhibitory concentration: 3910 nM
For compound 3 the middle estimate is 2.6-fold (0.42 log units) below the measured one, within the range that was stated.
By their numbers in this assay, from the lowest: compounds 2 and 1 (each within the scatter of the next); then compound 3.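

In this assay this position on the carbonyl carbon responds to a change of group, which the two cyclohexyl stereoisomers did not show: 3-methoxypyrrolidin-1-yl in place of (4-methoxycyclohexyl)amino gives a 4.1-fold higher number from compound 2 to compound 3 (0.61 log units; beyond the scatter) and a 2.9-fold higher number from compound 1 to compound 3 (0.46 log units; beyond the scatter) in the same change. Both steps are modest, and the swap alters ring size, ring make-up and the hydrogen-bond donor count together, so the result cannot be assigned to any one of these. Nothing measured here bears on the cause of this step.

Still open, as far as these compounds go, is whether the amide hydrogen or the ring accounts for the step, which a piperidin-1-yl or a (3-methoxycyclopentyl)amino group on the carbonyl carbon would separate. Also open, from the compounds shown here alone, is what the methoxy group contributes, as against a hydroxyl group or a carboxylic acid on the same ring.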